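The source may hold more compounds than are shown below. What is called first, only, known or untested is meant among the compounds shown, and "the series" means these compounds.

In a functional assay on PANC-1 cells (Homo sapiens), read by microscopy, crystal violet staining and transwell migration, with a stated time of 18 h, in the presence of a further agent that is not named here (a lower number here means a stronger inhibitor, a higher number a weaker inhibitor), compound 2 `CCOc1ccc(-c2nc(CC)nn2-c2cccc(C(=O)NCCCCc3ccccc3)c2)cc1` gives 16800 nM as the higher of the two numbers measured, and compound 1 `CCc1nc(-c2ccc(OC)cc2)n(-c2cccc(C(=O)NCCCCc3ccccc3)c2)n1` gives 140 nM as the lower. Compound 3 `CCc1nc(-c2ccc(OC(F)F)cc2)n(-c2cccc(C(=O)NCCCCc3ccccc3)c2)n1` differs from compound 2 by difluoromethyl in place of ethyl on an oxygen on an aromatic ring as difluoromethyl in place of ethyl on an oxygen on an aromatic ring. Among the compounds with values here, one measured step bears on this place: a 120-fold higher number from compound 1 to compound 2 (2.08 log units; beyond the scatter) is large, and it comes with methyl in place of hydrogen on a saturated chain carbon bound to an oxygen on an aromatic ring. No fluorinated group has been measured, so the size of the coming step is uncertain. With compound 1 at 140 nM as the guide, this assay is expected to show a sizeable move to a lower number, and an 11-fold lower number from compound 2 to compound 3 (1.05 log units; beyond the scatter) is the estimated step. Compound 3 is estimated at 1500 nM with an expected range of 250 nM to 10000 nM in all.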

Compound 3, half-maximal inhibitory concentration: 830 nM
For compound 3 the middle estimate is 1.8-fold (0.26 log units) above the measured one; measured number inside the range.
By their numbers in this assay, from the lowest: compound 1; then compound 3; then compound 2.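

In this assay, replacing ethyl with difluoromethyl gives a 20-fold lower number from compound 2 to compound 3 (1.31 log units; beyond the scatter) while replacing methyl with it gives a 5.9-fold higher number from compound 1 to compound 3 (0.77 log units; beyond the scatter) so on this oxygen the fluorinated group falls between the other two. Heavy-atom count alone does not set this order, since difluoromethyl with 3 heavy atoms gives a lower number than ethyl with 2. Nothing available explains the order. On these data alone, what trifluoromethyl, a bare hydroxyl or an amine would give in this place stays open. So does whether the same order holds with a shorter chain on the amide.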